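From sec-butyl to butyl on an amine nitrogen

A few compounds are considered here, and "the series" means these few. Any claim that something is new, unique, unknown or untested is made for them only; others in the source may bear on it.

Measured values in an ADME assay on EA.hy 926 cells (Homo sapiens) for inhibition, read by MTT assay, with a stated time of 72 h; a lower number here means a stronger inhibitor, a higher number a weaker inhibitor:
- compound 1 `CCC(C)NC(=C\C(=O)/C=C/c1ccc(O)c(OC)c1)/C=C/c1ccc(O)c(OC)c1`: > 25000 nM (a limit)
- compound 2 `CC(C)CNC(=C\C(=O)/C=C/c1ccc(O)cc1)/C=C/c1ccc(O)cc1`: > 25000 nM (a limit)
- compound 3 `CCC(C)NC(=C\C(=O)/C=C/c1ccc(O)cc1)/C=C/c1ccc(O)cc1`: 22000 nM

In this assay compound 1 gives > 25000 nM, which is a limit and not a number. Compound 1 therefore stands at the limit of > 25000 nM in this assay, at which 2 of the 3 values shown sit. The next compound to be tested is compound 4 `CCCCNC(=C\C(=O)/C=C/c1ccc(O)c(OC)c1)/C=C/c1ccc(O)c(OC)c1`, which has butyl in place of sec-butyl on an amine nitrogen. The same atoms are present, joined differently.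

Going by the values given here, no measured step makes this exact change. The nearest one also alters the chain on the amine nitrogen, though on a different pair of compounds: an at least 1.1-fold lower number from compound 2 to compound 3 (0.05 log units; that floor lies within the scatter). That small step gives no reason to expect a change beyond the scatter, so no clear step up or down is expected in this assay. The expected step is a number no higher from compound 1 to compound 4 (the limit leaves the size open). For compound 4 the estimated value is 25000 nM, with an expected range from 12000 nM to 40000 nM.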

Compound 4, half-maximal inhibitory concentration: > 25000 nM
Compound 4 ended at the assay's limit; the forecaster's own chance of this, stated with the estimate: 65%; the middle value sits exactly at the limit.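

Compound 1 and compound 4 both end at a limit of the assay and not at a number, so the step from sec-butyl to butyl cannot be read: the limit of > 25000 nM in this assay, at which 3 of the 4 values shown sit.

From the compounds shown here alone, whether this change of chain on the amine nitrogen alters inhibition at all stays open.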